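Swapping Methyl for Trifluoromethyl on a Thiazole Amide

A few compounds are considered here, and "the series" means these few. Any claim that something is new, unique, unknown or untested is made for them only; others in the source may bear on it.

Compound 2 `Cc1csc(NC(=O)[C@H](c2ccc(Cl)cc2)C(C)C)n1` is one of two compounds tested in a functional assay on CHO cells for agonist activity at Free fatty acid receptor 2 (Homo sapiens), read by cAMP accumulation; a lower number here means a smaller maximal response, a higher number a larger maximal response. In this assay compound 2 gives 87%, the higher of the two numbers. Among the compounds with values here, its neighbour, compound 1 `CC(C)[C@H](C(=O)Nc1cnns1)c1ccc(Cl)cc1`, gives 48% in this assay, and the only measured step, a number 39 percentage points higher from compound 1 to compound 2 (beyond the scatter), exchanges one ring for another on the amide-type nitrogen. Compound 3 `CC(C)[C@H](C(=O)Nc1nc(C(F)(F)F)cs1)c1ccc(Cl)cc1` keeps the core of compound 2 and alters a single group: trifluoromethyl in place of methyl on an aromatic carbon. Within the data shown here, no measured step touches this group, so the size of the step cannot be read from the data, and the one step at hand concerns a ring exchange that does not bear on it. A change confined to one group is expected to move the number by less than that ring exchange did, in either direction, and compound 3 is estimated at 80%, between 55% and 100%, which means a number 7 percentage points lower from compound 2 to compound 3 (within the scatter).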

Compound 3, largest response reached (reported as efficacy), in percent of the reference or control that the assay uses: 123%
Beside the measured number, compound 3's estimate is 43 percentage points below it; measured number outside the range, above it.
By their numbers in this assay, from the lowest: compound 1; then compound 2; then compound 3.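

In this assay, placing trifluoromethyl instead of methyl on the carbon next to the ring nitrogen gives a number 36 percentage points higher from compound 2 to compound 3 (beyond the scatter). This shows that the maximal response is sensitive to this position: a change confined to one group, with the rest of the molecule kept, produces a large step, just as the ring exchange did, which gave a number 39 percentage points higher from compound 1 to compound 2 (beyond the scatter). Nothing available explains why this exchange raises the response.

With only methyl and trifluoromethyl shown at this carbon, it remains open whether the fluorine atoms matter in themselves or whether a group such as ethyl, a chlorine atom or a nitrile would do the same. A plain hydrogen at this carbon would show how much of the response needs any group there at all.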